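Urea series: aryl swap on the urea nitrogen of compound 3

A few compounds are considered here, and "the series" means these few. Any claim that something is new, unique, unknown or untested is made for them only; others in the source may bear on it.

Measured so far:
compound 1, `O=C(Nc1ccc(Cl)cc1)Nc1ccc(Oc2ccc(-c3nccs3)cc2)cc1`, 32.5%
compound 2, `Cc1ccc(NC(=O)Nc2ccc(Oc3ccc(-c4nccs4)cc3)cc2)cc1`, 22.8%
compound 3, `O=C(Nc1ccc(Cl)cc1)Nc1ccc(Oc2ccc(-c3ncc[nH]3)cc2)cc1`, 47.6%

In a functional assay on MDA-MB-231 cells (Homo sapiens) for inhibition, read by MTT assay and WST assay, with a stated time of 72 h, tested at 10 uM (on this read-out higher numbers stand for more inhibition of growth at the one concentration tested and lower numbers for less inhibition of growth), compound 3 gives the highest number of the three; the step of a number 15.1 percentage points higher from compound 1 to compound 3 (beyond the scatter) lies beyond the scatter, and compound 2 stands further below it. Among the measured compounds shown here, the one change on the chlorophenyl ring measured so far, a number 9.7 percentage points lower from compound 1 to compound 2 (within the scatter), stays within the scatter.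

Compound 4, `O=C(Nc1ccc(Oc2ccc(-c3ncc[nH]3)cc2)cc1)Nc1cccc(C(F)(F)F)c1`, differs from compound 3 by 3-(trifluoromethyl)phenyl in place of 4-chlorophenyl on an amide-type nitrogen. For the measured compounds named here, no measured step covers a trifluoromethyl group or this ring, so only the small chloro-to-methyl step informs the guess. A step within the scatter is expected, a number 0.6 percentage points lower from compound 3 to compound 4 (within the scatter), and compound 4 is estimated at 47% (range 30% to 64%).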

Compound 4, percent growth inhibition at one concentration: 28.1%
The estimate for compound 4 lay 18.9 percentage points above the measured number; measured number outside the range, below it.
By their numbers in this assay, from the lowest: compounds 2, 4 and 1 (each within the scatter of the next); then compound 3.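

Among the compounds shown here, the aryl group on this amide-type nitrogen matters in this assay: a number 19.5 percentage points lower from compound 3 to compound 4 (beyond the scatter), whereas the only earlier change on this ring, a number 9.7 percentage points lower from compound 1 to compound 2 (within the scatter), did not separate its two compounds. Because the group and its substitution pattern change together in this swap, the step cannot be assigned to either one alone. Nothing measured here accounts for the loss.

Still open, from the compounds shown here alone, is how a nitrile or an amine on this ring would compare. Going by these compounds, it is also open whether the same swap has a similar effect with the 1,3-thiazol-2-yl group of compound 1.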